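This account rests on a few compounds, and the source may have more. Where it says the series, first, only, none or still open, it means among the compounds named here.

In an ADME assay on NIH3T3 cells (Mus musculus) for cytotoxicity, read by MTT assay, with a stated time of 24 h (a higher number here means a weaker inhibitor, a lower number a stronger inhibitor), compound 1, `Cn1cnnc1SCCc1nnc(SCC(=O)Nc2ccc(Cl)cc2)o1`, gives only a limit, > 500 ug/mL. Compound 2, `Cn1cnnc1SCCc1nnc(SCC(=O)Nc2nc3ccc(Cl)cc3s2)o1`, gives 422 ug/mL in this assay. Compound 3, `Cn1cnnc1SCCc1nnc(SCC(=O)Nc2nc3ccc([N+](=O)[O-])cc3s2)o1`, also gives only a limit in this assay, > 500 ug/mL. For the measured compounds named here, the single measured step, an at least 1.1-fold higher number from compound 2 to compound 3 (0.07 log units; that floor lies within the scatter), sits within the scatter and shows no clear movement. Compound 4, `COc1ccc(NC(=O)CSc2nnc(CCSc3nncn3C)o2)cc1`, differs from compound 1 by methoxy in place of chloro on an aromatic carbon. Going by the values given here, no measured step exchanges a chloro for a methoxy, so the only guidance is the limit of > 500 ug/mL in this assay, at which 2 of the 3 values shown sit, and no step beyond the scatter is expected in this assay in either direction. Compound 4 is therefore expected to give about 500 ug/mL, between 300 ug/mL and 1000 ug/mL. The expected step is a number no higher from compound 1 to compound 4 (the limit leaves the size open).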

Compound 4, half-maximal inhibitory concentration: > 500 ug/mL
Compound 4 was reported as a limit (the forecaster's own chance of this, stated with the estimate: 70%); the middle value lies on the limit itself.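

For the compounds shown here, compound 1 and compound 4 are both reported only as limits in this assay, so no step between them can be read. The compounds shown leave open whether methoxy in place of chloro moves the number in this assay at all.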